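This account rests on a few compounds, and the source may have more. Where it says the series, first, only, none or still open, it means among the compounds named here.

In a functional assay on NCI-H460 cells (Homo sapiens) for inhibition, read by MTT assay, with a stated time of 24 h, tested at 1 ug/mL (a higher number here means more inhibition of growth at the concentration tested, a lower number less inhibition of growth), three compounds sharing one core have been measured. Compound 1 (`O=C(CCCCC(S)CCS)NO`) gives 1.17% and compound 2 (`O=C(CCCCC(S)CCS)Nc1ccccc1`) gives 4.3% while compound 3 (`O=C(CCCCC(S)CCS)Nc1cccc(Cl)c1`) gives 7.2% on the same scale. Compound 2 shows no separation from the other two, as its value lies within the scatter of each. Compound 4 (`O=C(CCCCC(S)CCS)Nc1ccc(F)cc1`) has not yet been measured. It differs from compound 2 by one change (fluoro in place of hydrogen on an aromatic carbon) which is fluoro in place of hydrogen on an aromatic carbon. The closest measured change is chloro in place of hydrogen on an aromatic carbon, which gave a number 2.9 percentage points higher from compound 2 to compound 3 (within the scatter) in this series. The other measured step, phenyl in place of hydroxy on an amide-type nitrogen, gave a number 3.1 percentage points higher from compound 1 to compound 2 (within the scatter) and is equally small. With only these two steps to go on, no step beyond the scatter is expected in this assay for the new change. The estimate amounts to a number 1.2 percentage points higher from compound 2 to compound 4 (within the scatter) as an expected step. Compound 4 is therefore expected at 5.5% with an estimated range from 0% to 14% as the likely span.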

Compound 4, percent growth inhibition at one concentration: 6.84%
Compound 4: the middle estimate sits 1.3 percentage points below what was measured, and the stated range covers the measured number.
By their numbers in this assay, from the lowest: compounds 1, 2, 4 and 3 (each within the scatter of the next).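

In this assay, fluoro in place of hydrogen on an aromatic carbon, para to a large group, gives a number 2.5 percentage points higher from compound 2 to compound 4 (within the scatter). This adds a second halogen change on the aromatic ring of compound 2, alongside the chloro change that gave a number 2.9 percentage points higher from compound 2 to compound 3 (within the scatter), and neither step separates its product from compound 2, so the series now shows this position taking a fluoro group without a step beyond the scatter. Nothing at hand speaks to what lies behind this step.

On these data alone, whether an amine or a carboxylic acid at this place on the ring would give a step beyond the scatter stays open, as does the effect of a longer chain in the shared core. Also open is whether these compounds would separate from one another at any concentration other than the single one shown.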